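Dropping One Chloro from a Dichlorophenyl Urea

The source may report more compounds than this note shows. Statements on the series, on what has been measured and on what is new or still open speak of the compounds shown alone.

Going by the values given here, compound 1 `Cc1cc(NC(=O)Nc2ccc(Cl)c(Cl)c2)c2ccccc2n1` is one of three compounds measured in an ADME assay for permeability, using PAMPA, at pH 7.4; a lower number here means that the compound crosses the layer more slowly, a higher number that the compound crosses the layer faster. In this assay compound 1 gives 197 10^-6 cm/s, the second highest of the three numbers. Its nearest neighbour is compound 3 `COc1ccc(NC(=O)Nc2cc(C)nc3ccccc23)cc1Cl`, which gives 336 10^-6 cm/s; the step of a 1.7-fold higher number from compound 1 to compound 3 (0.23 log units; within the scatter) is within the scatter, so the two cannot be told apart. Far below both is compound 2 `Cc1cc(NC(=O)Nc2ccc3[nH]cnc3c2)c2ccccc2n1`, which gives 2 10^-6 cm/s.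

Compound 4 `Cc1cc(NC(=O)Nc2ccc(Cl)cc2)c2ccccc2n1` is the next step from compound 1. Among the compounds with values here, the change is hydrogen in place of chloro on an aromatic carbon The only measured step that bears on it, a 1.7-fold higher number from compound 1 to compound 3 (0.23 log units; within the scatter), exchanged one group for another at an aromatic carbon and stayed within the scatter. Within the data shown here, no measured step removes a group outright, and compound 2 tells only that a large rebuild of the ring can matter, not what losing a chloro does. A step of a 1.3-fold lower number from compound 1 to compound 4 (0.12 log units; within the scatter) is therefore expected, no further than the scatter allows. Compound 4 is estimated at 150 10^-6 cm/s, within a range from 60 10^-6 cm/s to 350 10^-6 cm/s.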

Compound 4, apparent permeability: 537 10^-6 cm/s
For compound 4 the middle estimate is 3.6-fold (0.55 log units) below the measured one; the measured number lies above the stated range.
By their numbers in this assay, from the lowest: compound 2; then compounds 1, 3 and 4 (each within the scatter of the next, the first and the last beyond it).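

In this assay, the step of a 2.7-fold higher number from compound 1 to compound 4 (0.44 log units; beyond the scatter) is modest but lies beyond the scatter, so this position on the aromatic ring does affect the number. Removing this one chloro, the one ortho to the remaining chloro and meta to the large group, takes away a single heavy atom and no hydrogen-bond donor or acceptor, yet the number moves upward. The earlier step of a 1.7-fold higher number from compound 1 to compound 3 (0.23 log units; within the scatter) changed the other chloro and stayed within the scatter, and nothing measured here explains the upward move.

The compounds shown leave open what a fluoro or an amine would do at this same position. They also leave open whether removing the other chloro outright, rather than exchanging it for methoxy, would shift the number as well.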